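This account rests on a few compounds, and the source may have more. Where it says the series, first, only, none or still open, it means among the compounds named here.

Measured compounds:

Compound 1, `COc1cc2c(/C=C3/C(=O)Nc4ccc(Cl)cc43)c(Cl)n(Cc3cc(OC)c(OC)c(OC)c3)c2cc1C`: 1860 nM
Compound 2, `COc1ccc2c(c1)/C(=C\c1c(Cl)n(Cc3cc(OC)c(OC)c(OC)c3)c3cc(C)c(OC)cc13)C(=O)N2`: 6170 nM
Compound 3, `COc1c(/C=C2/C(=O)Nc3ccc(Cl)cc32)c2ccccc2n1-c1ccccc1`: 2340 nM

In a functional assay on cells (Leukemia cell, Homo sapiens) for cytotoxicity, with a stated time of 48 h (a higher number here means a weaker inhibitor of growth, a lower number a stronger inhibitor of growth), compound 1 gives 1860 nM. Compound 2 carries methoxy in place of chloro on an aromatic carbon, and in this assay compound 2 gives 6170 nM, so that a 3.3-fold higher number from compound 1 to compound 2 (0.52 log units; beyond the scatter). Compound 3 has a different core, and the difference between the two cores is not broken down here; in this assay compound 3 gives 2340 nM. Compound 3 and compound 1 lie within the scatter of each other, while compound 3 and compound 2 lie beyond it.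

Compound 4, `COc1ccc2c(c1)/C(=C\c1c(OC)n(-c3ccccc3)c3ccccc13)C(=O)N2`, has not been measured. It differs from compound 3 by methoxy in place of chloro on an aromatic carbon. This is the same change as that between compound 1 and compound 2, made at the same kind of place, and it occurs twice among the compounds shown. Going by the values given here, only that one earlier step, with its own core, is available to judge it, so the expectation rests on a single pair. The estimate for compound 4 in this assay is that a 3.0-fold higher number from compound 3 to compound 4 (0.48 log units; beyond the scatter), expected to match the modest step seen from compound 1 to compound 2. On that basis compound 4 is expected to give about 7000 nM, with a likely range from 3000 nM to 16000 nM.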

Compound 4, concentration for 50% growth inhibition: 760 nM
Beside the measured number, compound 4's estimate is 9.2-fold (0.96 log units) above it; the whole stated range lies above it.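

In this assay, putting methoxy in place of chloro on an aromatic carbon gives a 3.1-fold lower number from compound 3 to compound 4 (0.49 log units; beyond the scatter), which runs opposite to the step seen with the same change on the core of compound 1. The size and direction of this change therefore do not carry from one core to the other in this series, and a step read on one core is a poor guide to the other: the same change on two cores in this assay, a 3.3-fold higher number (0.52 log units; beyond the scatter) from compound 1 to compound 2 and a 3.1-fold lower number (0.49 log units; beyond the scatter) from compound 3 to compound 4, 10-fold (1.01 log units) apart, beyond the scatter of two such steps. This does not show which of the several differences between the two cores goes with the reversal, and two pairs give no rule for what the same change would do on a third core.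

The compounds shown leave open how other groups on this aromatic carbon, such as fluoro, an amine or a longer alkoxy chain, would compare with chloro and methoxy on each core. They also leave open whether a core carrying only some of the differences between the two cores would follow the step of compound 2 or that of compound 4, which is the comparison that could begin to separate those differences.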